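The source may report more compounds than this note shows. Statements on the series, on what has been measured and on what is new or still open speak of the compounds shown alone.

Three compounds built on one shared core have been put through an ADME assay on MOLT-3 cells (Homo sapiens) for cytotoxicity, with a stated time of 7 days; on this read-out higher numbers stand for lower toxicity in this test and lower numbers for higher toxicity in this test: compound 1 `Nc1nc(NC2CC2)c2ncn(/C=C3/CC3(CO)CO)c2n1`, compound 2 `Nc1nc(N2CCCC2)c2ncn(/C=C3/CC3(CO)CO)c2n1` and compound 3 `CSc1nc(N)nc2c1ncn2/C=C1/CC1(CO)CO`. Compound 1 gives > 20000 nM, which is a limit of the assay and not a number. Compound 3 gives > 20000 nM, and this too is a limit. For compound 2 the entry reads "not determined" (no result reported). Compound 3 therefore has no number of its own, and what the series offers so far is the limit of > 20000 nM in this assay, at which 2 of the 3 values shown sit.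

The next compound, compound 4 `CCCCOc1nc(N)nc2c1ncn2/C=C1/CC1(CO)CO`, departs from compound 3 by a single change: butoxy in place of methylsulfanyl on an aromatic carbon. In words, this is butoxy in place of methylsulfanyl on an aromatic carbon. For the measured compounds named here, only one measured step bears on it, because a step that the two limits leave unreadable from compound 1 to compound 3 also swaps the group on an aromatic carbon. That step has no readable size, so no magnitude can be carried over. In this assay the expectation is therefore no step beyond the scatter in either direction, with compound 4 staying close to the limit. The step of a number no higher from compound 3 to compound 4 (the limit leaves the size open) is the estimated one. For compound 4 the expected value is 20000 nM, with an estimated range from 8000 nM to 40000 nM.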

Compound 4, half-maximal cytotoxic concentration: > 20000 nM
Compound 4 gave a limit, no number (the forecaster's own chance of this, stated with the estimate: 70%); the middle value sits exactly at the limit.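

In this assay compound 4 gives > 20000 nM, which is a limit of the assay and not a number. The steps linking compound 4 with compound 1 and compound 3 therefore cannot be read. The series still offers only this: the limit of > 20000 nM in this assay, at which 3 of the 4 values shown sit. The compounds shown leave open what actual cytotoxic concentration any of these three compounds has.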